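This account rests on a few compounds, and the source may have more. Where it says the series, first, only, none or still open, it means among the compounds named here.

Three ureas have so far been measured in an ADME assay on the whole organism with Oryza sativa as the target, tested at 0.1 uM; on this read-out higher numbers stand for a weaker effect at the one concentration tested and lower numbers for a stronger effect. Compound 1 `C[C@H](NC(=O)Nc1ccccc1C(C)(C)C)c1ccccc1` gives 101%. Compound 2 `C[C@@H](NC(=O)Nc1ccccc1F)c1ccccc1` gives 97%, and compound 3 `C[C@H](NC(=O)Nc1ccccc1F)c1ccccc1` gives 98%. Compound 3 therefore stands among numbers that are all close together: the step from compound 1 is a number 3 percentage points lower from compound 1 to compound 3 (within the scatter), and the step from compound 2 is a number 1 percentage points higher from compound 2 to compound 3 (within the scatter), a comparison that rests on (the fact that compounds 2 and 3 differ only in the configuration as drawn). Compound 4 `C[C@H](NC(=O)Nc1cc(C(F)(F)F)ccc1F)c1ccccc1` is not yet measured; it differs from compound 3 by trifluoromethyl in place of hydrogen on an aromatic carbon. Both measured steps concern a change on the same core, and neither moved the read-out beyond the scatter, so only a small shift is expected a number 3 percentage points lower from compound 3 to compound 4 (within the scatter). Compound 4 is estimated at 95%, with a range from 80% to 105%.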

Compound 4, a percentage reported as activity, at one concentration (the size of the read-out at that concentration, not a potency): 98%
Compound 4: the middle estimate sits 3 percentage points below what was measured; measured number inside the range.
By their numbers in this assay, from the lowest: compounds 2, 3, 4 and 1 (each within the scatter of the next).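

In this assay, trifluoromethyl in place of hydrogen gives no change at the digits printed from compound 3 to compound 4 (within the scatter). Among these compounds, the earlier steps changed only the group at another ring place and the configuration, so this is the first sign that a substituent at this place, meta to a large group and para to a fluoro group, can enter without moving the read-out beyond the scatter. Nothing measured here bears on why this step behaves as it does. On these data alone, whether an amine or a carboxylic acid at this same place would leave the number as undisturbed stays open. So does whether any change to the shared core can move this read-out beyond the scatter.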